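This account rests on a few compounds, and the source may have more. Where it says the series, first, only, none or still open, it means among the compounds named here.

Measured so far:
compound 1 `Cc1ccc(N)cc1S(=O)(=O)N(C)/N=C/c1cnn2ccc(C#N)cc12` — > 1000 nM
compound 2 `Cc1ccc(C)c(S(=O)(=O)N(C)/N=C/c2cnn3ccc(C#N)cc23)c1` — > 1000 nM

In an assay on isolated protein for inhibition of phosphatidylinositol 4,5-bisphosphate 3-kinase catalytic subunit beta isoform (Homo sapiens), read by 33P incorporation, with a stated time of 60 min (a lower number here means a stronger inhibitor, a higher number a weaker inhibitor), compound 2 gives > 1000 nM, which is a limit of the assay and not a number. Compound 1 likewise gives a limit in this assay, > 1000 nM. The step that the two limits leave unreadable from compound 1 to compound 2 therefore stays unreadable, since both values sit at the limit of > 1000 nM in this assay, at which 2 of the 2 values shown sit. Compound 3 `Cc1ccc(Br)cc1S(=O)(=O)N(C)/N=C/c1cnn2ccc(C#N)cc12` differs from compound 2 by bromo in place of methyl on an aromatic carbon. Going by the values given here, no measured step in this assay bears on that change, as the only step available is unreadable. The expected step that the limit leaves unreadable from compound 2 to compound 3 is taken as none beyond the scatter, and compound 3 is expected to remain at or near the limit. Estimate for compound 3: 2000 nM, range 600 nM to 8000 nM.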

Compound 3, half-maximal inhibitory concentration: 620 nM
Beside the measured number, compound 3's estimate is 3.2-fold (0.51 log units) above it, and the stated range covers the measured number.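

In this assay, going by these compounds alone, compound 3 is the first compound to give a number and not a limit, so bromo, at this carbon meta to a large group and para to a methyl group, can be read on the scale. The data give an at least 1.6-fold lower number from compound 2 to compound 3 (0.20 log units; that floor lies within the scatter) and an at least 1.6-fold lower number from compound 1 to compound 3 (0.20 log units; that floor lies within the scatter); both are floors only, so neither establishes a difference beyond the scatter. The step from compound 1 to compound 2 cannot be read.

Open, as far as these compounds go, is how chloro, methoxy or a longer chain such as ethyl would read at this carbon. Also open, from the compounds shown here alone, is how far the true values of compound 1 and compound 2 lie from that of compound 3.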